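Replacing the fluorophenyl on the amino nitrogen with hydroxyethyl

The compounds below may be only part of what the source reports. "The series", "measured", "known", "first", "only" and "open" are said of these compounds alone.

Of the two numbers shown in a functional assay on ECa-109 cells (Homo sapiens) for cytotoxicity, read by MTT assay, with a stated time of 72 h (a higher number here means a weaker inhibitor, a lower number a stronger inhibitor), compound 3 `Cc1cc(Nc2ccc(F)cc2)nc(SCc2nc3ccccc3[nH]2)n1` gives 69500 nM and compound 1 `Cc1ccc(Nc2cc(C)nc(SCc3nc4ccccc4[nH]3)n2)cc1` gives 57300 nM; the step of a 1.2-fold higher number from compound 1 to compound 3 (0.08 log units; within the scatter) lies within the scatter. Compound 2 `Cc1cc(N2CCNCC2)nc(SCc2nc3ccccc3[nH]2)n1` reaches only a limit, > 100000 nM, as noted in the limit of > 100000 nM in this assay, at which 1 of the 3 values shown sits. Compound 4 `Cc1cc(NCCO)nc(SCc2nc3ccccc3[nH]2)n1` differs from compound 3 by 2-hydroxyethyl in place of 4-fluorophenyl on a nitrogen on an aromatic ring. The closest measured comparison is an at least 1.7-fold higher number from compound 1 to compound 2 (0.24 log units; that floor lies within the scatter), where piperazin-1-yl replaced (4-methylphenyl)amino, and an at least 1.4-fold lower number from compound 2 to compound 3 (0.15 log units; that floor lies within the scatter) points the same way: removing the aromatic amine substituent has not helped. Compound 4 is therefore expected to weaken, likely to the limit, by an estimated 1.7-fold higher number from compound 3 to compound 4 (0.24 log units; within the scatter). Compound 4 is estimated at 120000 nM, expected between 50000 nM and 300000 nM.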

Compound 4, half-maximal inhibitory concentration: > 100000 nM
Compound 4 was reported as a limit; the forecaster's own chance of this, stated with the estimate: 60%; the middle value does not contradict the limit.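

In this assay, compound 4 gives a limit rather than a number, so replacing 4-fluorophenyl with 2-hydroxyethyl on this nitrogen can be read only as a floor: an at least 1.4-fold higher number from compound 3 to compound 4 (0.15 log units; that floor lies within the scatter), and an at least 1.7-fold higher number from compound 1 to compound 4 (0.24 log units; that floor lies within the scatter). An open chain, and not only the piperazin-1-yl ring of compound 2, now ends at the same limit: the limit of > 100000 nM in this assay, at which 2 of the 4 values shown sit. The step between compound 2 and compound 4 cannot be read, as both are limits.

On these data alone, it remains open how far compound 2 and compound 4 lie beyond that limit. As far as these compounds go, it is also open whether a phenyl ring carrying a carboxylic acid, or a longer chain ending in an amine, would give a readable number at this nitrogen.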